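The source may hold more compounds than are shown below. What is called first, only, known or untested is meant among the compounds shown, and "the series" means these compounds.

Measured compounds:
compound 1, `Cc1cccc(Cc2cnc(CCc3ccc(-c4ccccc4C(=O)O)cc3)[nH]2)c1`, 75 nM
compound 2, `O=C(O)c1ccccc1-c1ccc(CCc2ncc(Cc3cccc(F)c3F)[nH]2)cc1`, 8 nM
compound 3, `Cc1ccccc1Cc1cnc(CCc2ccc(-c3ccccc3C(=O)O)cc2)[nH]1`, 9.3 nM

In an in vitro functional assay on cells for agonist activity at Bombesin receptor subtype-3 (Mus musculus), read by luminescence and calcium flux (a higher number here means that more compound is needed for the effect, a lower number that less compound is needed), compound 3 gives 9.3 nM, the second highest number of the three; compound 2, at 8 nM, lies within the scatter of it (a 1.2-fold higher number from compound 2 to compound 3 (0.07 log units; within the scatter)), while compound 1 stands apart (an 8.1-fold lower number from compound 1 to compound 3 (0.91 log units; beyond the scatter)).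

Compound 4, `CC(C)CCc1cnc(CCc2ccc(-c3ccccc3C(=O)O)cc2)[nH]1`, is not yet measured. isobutyl in place of 2-methylphenyl on a saturated chain carbon bound to an aromatic carbon The measured steps all concern the pattern of substituents on the phenyl ring at that saturated chain carbon: an 8.1-fold lower number from compound 1 to compound 3 (0.91 log units; beyond the scatter) and a 9.4-fold lower number from compound 1 to compound 2 (0.97 log units; beyond the scatter) were both modest, and a 1.2-fold higher number from compound 2 to compound 3 (0.07 log units; within the scatter) lay within the scatter. None of them exchanges the ring for an open chain, so they give no direct guide to the step estimated here, a 4.3-fold higher number from compound 3 to compound 4 (0.63 log units; beyond the scatter). Because the modest steps were seen only among phenyl variants (an 8.1-fold lower number from compound 1 to compound 3 (0.91 log units; beyond the scatter)), a loss of roughly that size is expected for compound 4, though one within the scatter cannot be excluded. Compound 4 is therefore estimated at 40 nM, with a range from 8 nM to 200 nM.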

Compound 4, half-maximal effective concentration: 10 nM
For compound 4 the middle estimate is 4.0-fold (0.60 log units) above the measured one, and the stated range covers the measured number.
By their numbers in this assay, from the lowest: compounds 2, 3 and 4 (each within the scatter of the next); then compound 1.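

In this assay, this position does not need an aromatic ring: with isobutyl in place of 2-methylphenyl on a saturated chain carbon bound to an aromatic carbon, the result is a 1.1-fold higher number from compound 3 to compound 4 (0.03 log units; within the scatter), and with isobutyl in place of 2,3-difluorophenyl it is a 1.3-fold higher number from compound 2 to compound 4 (0.10 log units; within the scatter). Compound 1 remains apart, with a 7.5-fold lower number from compound 1 to compound 4 (0.88 log units; beyond the scatter), so among these four compounds the 3-methylphenyl group is the one substituent that goes against an otherwise flat picture. Nothing available here explains why the open chain and the two ring groups give such similar numbers.

On these data alone, whether a shorter chain, a longer chain or a cyclohexyl ring would behave like isobutyl remains open. So does the effect of an amine or a hydroxyl group on that chain.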